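The compounds below may be only part of what the source reports. "The series", "measured", "known", "first", "only" and "open" are said of these compounds alone.

Measured so far:
- compound 1, `COc1ccc2nc(C)cc(OCC(=O)NCc3cc(C)cc(C)c3)c2c1`: in a toxicity assay on HepG2 cells (Homo sapiens) for inhibition, read by CellTiter-Glo, with a stated time of 48 h (a higher number here means a weaker inhibitor, a lower number a stronger inhibitor), compound 1 gives > 100000 nM, which is a limit of the assay.
- compound 2, `COc1ccc2nc(C)cc(OCC(=O)Nc3c(C)cccc3C)c2c1`: in this assay compound 2 gives > 100000 nM, also a limit of the assay.
- compound 3, `COc1ccc2nc(C)cc(OCC(=O)Nc3ccc(F)cc3)c2c1`: in this assay compound 3 gives 63100 nM.

Within the data shown here, compound 3 thus holds the only number; the other two values sit at the limit of > 100000 nM in this assay, at which 2 of the 3 values shown sit. The step that the two limits leave unreadable from compound 1 to compound 2 cannot be read. The steps of an at least 1.5-fold lower number from compound 1 to compound 3 (0.19 log units; that floor lies within the scatter) and an at least 1.5-fold lower number from compound 2 to compound 3 (0.19 log units; that floor lies within the scatter) give only a floor, and that floor lies within the scatter, so no real difference between the three is established.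

Compound 4, `COc1ccc2nc(C)cc(OCC(=O)Nc3ccncn3)c2c1`, has not been measured. It differs from compound 3 as follows: pyrimidin-4-yl in place of 4-fluorophenyl on an amide-type nitrogen. Among the measured compounds shown here, none of the measured steps touches a heteroaromatic ring on the amide nitrogen, so they give no direction for this change beyond showing that the series sits near the top of the measurable range. The expected step of a 1.3-fold higher number from compound 3 to compound 4 (0.10 log units; within the scatter) is therefore one within the scatter, with a fair chance that only a limit is returned. For compound 4 the estimate in this assay is 80000 nM, with a range from 30000 nM to 200000 nM.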

Compound 4, half-maximal inhibitory concentration: > 100000 nM
Compound 4 ended at the assay's limit; the forecaster's own chance of this, stated with the estimate: 45%; middle value at least 1.2-fold (0.09 log units) away from the limit.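

Pyrimidin-4-yl is the only ring with hetero atoms on the amide-type nitrogen among the compounds shown, and in this assay its exchange for 4-fluorophenyl gives an at least 1.5-fold higher number from compound 3 to compound 4 (0.19 log units; that floor lies within the scatter). This gives no sign of stronger inhibition with this ring at this position, but only a floor is available, so no real difference between the two compounds is established, and the steps from compound 1 and from compound 2 to compound 4 cannot be read. Compound 3 remains the only compound with a number, and the series otherwise reads as limits: the limit of > 100000 nM in this assay, at which 3 of the 4 values shown sit.

From the compounds shown here alone, whether compound 3 truly differs from the other three remains open. Also open, going by these compounds, is whether a pyridin-2-yl ring, an aminophenyl group, a carboxylic acid or a longer chain on this nitrogen would give a clear step in this assay.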